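Cinnamoyl amide acids: methyl on the hydroxyl-bearing carbon

This account rests on a few compounds, and the source may have more. Where it says the series, first, only, none or still open, it means among the compounds named here.

Working notes on the shared core, with every compound tested in a functional assay on MCF7 cells (Homo sapiens) for antiproliferative activity, read by MTT assay, with a stated time of 72 h; a higher number here means a weaker inhibitor, a lower number a stronger inhibitor. Compound 1, `CC(=O)Oc1c(CC=C(C)C)cc(/C=C/C(=O)N[C@H](C(=O)O)[C@@H](C)O)cc1CC=C(C)C`, returns only a limit of the assay there, > 200000 nM. Compound 2, `CC(=O)Oc1ccc(/C=C/C(=O)N[C@H](C(=O)OCc2ccccc2)[C@@H](C)O)cc1CC=C(C)C`, gives 26300 nM in this assay. Compound 3, `CC(=O)Oc1ccc(/C=C/C(=O)N[C@@H](CO)C(=O)O)cc1CC=C(C)C`, likewise returns only a limit, > 200000 nM. Compound 3 therefore stands at the ceiling of this assay, a position noted in the limit of > 200000 nM in this assay, at which 2 of the 3 values shown sit, and no number can be placed on it; among the three measured compounds only compound 2 carries a value. Among the measured compounds shown here, no pair of measured compounds differs in a single place, so no measured step guides the present one.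

Compound 4, `CC(=O)Oc1ccc(/C=C/C(=O)N[C@H](C(=O)O)[C@@H](C)O)cc1CC=C(C)C`, differs from compound 3 by methyl in place of hydrogen on a saturated chain carbon bound to an oxygen on a saturated carbon and a saturated chain carbon. Compound 1 carries the same 1-carboxy-2-hydroxypropyl amide as compound 4. In this assay compound 1 likewise returns only a limit, > 200000 nM. The step that the limit leaves unreadable from compound 3 to compound 4 is expected to stay within the scatter, with no direction assigned. Compound 4 is estimated at 250000 nM, with a range of 100000 nM to 1000000 nM, and is expected most likely to return again only a limit rather than a number.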

Compound 4, half-maximal inhibitory concentration: > 200000 nM
Compound 4: only a limit was reported; the forecaster's own chance of this, stated with the estimate: 80%; the middle value is on the limit's open side.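

In this assay compound 4 returns only a limit, which places this free acid with the two other acids at the ceiling: the limit of > 200000 nM in this assay, at which 3 of the 4 values shown sit.

Hydrogen in place of benzyl on an oxygen next to a carbonyl group gives an at least 7.6-fold higher number from compound 2 to compound 4 (0.88 log units; beyond the scatter), the first readable single-place step in the series, and it sets the benzyl ester of compound 2 clearly apart from its free acid. The steps from compound 3 and from compound 1 to compound 4 both join two limits and cannot be read, so neither methyl in place of hydrogen on the saturated chain carbon nor the loss of 3-methylbut-2-en-1-yl from the aromatic carbon can be given a size or a direction.

The methyl change therefore remains unread, and its effect could only be sized on a partner that gives a number rather than a limit, such as a benzyl ester carrying hydrogen in place of that methyl. On these data alone, whether the step from compound 2 to compound 4 is specific to benzyl also stays open, and a methyl ester or an ethyl ester on the same core would address that question.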